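From a Hydroxyethyl Chain to a Carboxyethyl Chain

This account rests on a few compounds, and the source may have more. Where it says the series, first, only, none or still open, it means among the compounds named here.

Of the compounds shown here, two sharing one core have been measured in a functional assay for antagonist activity at transient receptor potential cation channel subfamily V member 1 (Homo sapiens); on this read-out lower numbers stand for stronger inhibition and higher numbers for weaker inhibition. Compound 1 `CC(C)OCc1nc(Nc2ccc(C(F)(F)F)cc2)c2ccc(-c3ncccc3C(F)(F)F)cc2n1` gives 0.3 nM. Within the data shown here, compound 2 `OCCc1nc(Nc2ccc(C(F)(F)F)cc2)c2ccc(-c3ncccc3C(F)(F)F)cc2n1`, which carries a 2-hydroxyethyl chain, gives 22 nM, the highest number of the two measured compounds; the only measured step, a 73-fold higher number from compound 1 to compound 2 (1.87 log units; beyond the scatter), shows how far the number rose when the chain was changed.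

Compound 3 `O=C(O)CCc1nc(Nc2ccc(C(F)(F)F)cc2)c2ccc(-c3ncccc3C(F)(F)F)cc2n1` has not yet been measured. It differs from compound 2 in one place: carboxy in place of hydroxy on a saturated chain carbon, two bonds along the chain from an aromatic carbon. Among the measured compounds shown here, no measured step describes a change of this kind, and the one step recorded concerns a different change at a different point of the chain, so it bears on it only loosely. Compound 3 is therefore expected to sit near compound 2, with a modest shift toward a higher number, a 2.7-fold higher number from compound 2 to compound 3 (0.44 log units; beyond the scatter). Compound 3 is estimated at 60 nM, within a range from 12 nM to 400 nM.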

Compound 3, half-maximal inhibitory concentration: 1630 nM
The estimate for compound 3 lay 27-fold (1.43 log units) below the measured number; measured number above the stated range.
By their numbers in this assay, from the lowest: compound 1; then compound 2; then compound 3.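

Changing the end of this chain matters more than a single hydroxy-to-carboxy swap might suggest: in this assay, carboxy in place of hydroxy gives a 74-fold higher number from compound 2 to compound 3 (1.87 log units; beyond the scatter), a large step. Across the series, a 5400-fold higher number from compound 1 to compound 3 (3.74 log units; beyond the scatter), so the chain alone moves the number over a very wide range while the rest of the molecule stays the same. Nothing available explains why the 2-carboxyethyl chain gives so much weaker inhibition than the 2-hydroxyethyl chain.

On these data alone, it remains open whether this loss belongs to the carboxylic acid itself or would persist with a methyl ester or a primary amide in its place. An amine at the end of the chain, or a longer chain carrying the carboxylic acid, could also show how far this loss extends.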